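A Chloro Added to the Dibromo Benzyl Oxime Ether

A few compounds are considered here, and "the series" means these few. Any claim that something is new, unique, unknown or untested is made for them only; others in the source may bear on it.

Measured values in a functional assay on HepG2 cells (Homo sapiens) for antiproliferative activity, read by MTT assay, with a stated time of 48 h (a lower number here means a stronger inhibitor, a higher number a weaker inhibitor), so far
- Compound 1 `O=[N+]([O-])c1cc(C(F)(F)F)cc([N+](=O)[O-])c1Oc1ccc(Br)cc1/C=N\OCc1ccccc1` gives 1180 nM as its value
- Compound 2 `O=[N+]([O-])c1cc(C(F)(F)F)cc([N+](=O)[O-])c1Oc1c(Br)cc(Br)cc1/C=N\OCc1ccccc1` gives 1480 nM as its value

Compound 2, at 1480 nM on this scale, cannot be told apart from compound 1. Compound 3 `O=[N+]([O-])c1cc(C(F)(F)F)cc([N+](=O)[O-])c1Oc1c(Br)cc(Br)cc1/C=N\OCc1ccccc1Cl` has not been measured yet. It differs from compound 2 by chloro in place of hydrogen on an aromatic carbon, with chloro in place of hydrogen on an aromatic carbon, so that benzyl becomes 2-chlorobenzyl. Going by the values given here, the only measured step that bears on this, a 1.3-fold higher number from compound 1 to compound 2 (0.10 log units; within the scatter) for a bromo in place of hydrogen, stayed small and sits at another place, so no shift beyond the scatter is expected in this assay here. The expected step is a 1.1-fold lower number from compound 2 to compound 3 (0.02 log units; within the scatter) by this estimate. Compound 3 is expected at 1400 nM within an estimated range from 650 nM to 3000 nM in this account.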

Compound 3, half-maximal inhibitory concentration: 2450 nM
Beside the measured number, compound 3's estimate is 1.8-fold (0.24 log units) below it, within the range that was stated.
By their numbers in this assay, from the lowest: compounds 1, 2 and 3 (each within the scatter of the next, the first and the last beyond it).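

In this assay, chloro in place of hydrogen on an aromatic carbon, turning benzyl into 2-chlorobenzyl, gives a 1.7-fold higher number from compound 2 to compound 3 (0.22 log units; within the scatter), so this change on the benzyl ring does not move the number beyond the scatter. Going by these compounds alone, it is the only reading on that ring, as compound 1 and compound 2 differ only on the other aromatic ring. No supporting measurement bears on this result. As far as these compounds go, whether a larger group at this place, such as a methoxy or an amine, would shift the number beyond the scatter stays open.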